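Bromo to Hydrogen on the Shared Core: Expected Cytotoxicity

This account rests on a few compounds, and the source may have more. Where it says the series, first, only, none or still open, it means among the compounds named here.

compound 1 `CN(C)CN1C(=O)C(=O)c2c(Br)cccc21`: 67800 nM
compound 2 `O=C1C(=O)N(CN2CCCCC2)c2cccc(Br)c21`: 66900 nM

In an ADME assay on MCF-10A cells (Homo sapiens) for cytotoxicity, read by sulforhodamine B assay, with a stated time of 48 h (on this read-out higher numbers stand for weaker inhibition of growth and lower numbers for stronger inhibition of growth), compound 1 gives 67800 nM, the highest of the two numbers recorded so far. Among the measured compounds shown here, its only neighbour is compound 2, and the step of a 1.0-fold lower number from compound 1 to compound 2 (0.01 log units; within the scatter) lies within the scatter, so the two compounds cannot be ordered against each other. That step changes only the group on the saturated chain carbon bound to the amide-type nitrogen, piperidin-1-yl in place of dimethylamino, and leaves the aromatic ring untouched.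

Compound 3 `CN(C)CN1C(=O)C(=O)c2ccccc21` differs from compound 1 in another place: hydrogen in place of bromo on an aromatic carbon. For the measured compounds named here, no measured step touches this position, so nothing among the recorded compounds speaks directly to the change; the one measured step concerns a different part of the molecule and is itself within the scatter. With both measured numbers lying close together and no measured change at the aromatic ring, the expected step in this assay is none beyond the scatter, a 1.0-fold higher number from compound 1 to compound 3 (0.01 log units; within the scatter). Compound 3 is therefore estimated at 70000 nM, with a range from 30000 nM to 160000 nM.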

Compound 3, concentration for 50% growth inhibition: 150000 nM
Compound 3: middle estimate off by 2.1-fold (0.33 log units), on the low side; the range from low to high includes it.
By their numbers in this assay, from the lowest: compounds 2 and 1 (each within the scatter of the next); then compound 3.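

Among the compounds shown here, the change from bromo to hydrogen on the aromatic carbon gives the first step in this assay that lies beyond the scatter, a 2.2-fold higher number from compound 1 to compound 3 (0.34 log units; beyond the scatter), and this step is modest. For the compounds shown here, the earlier step on the chain, a 1.0-fold lower number from compound 1 to compound 2 (0.01 log units; within the scatter), showed no separation between its compounds, whereas this position on the ring does alter the read-out, with compound 1, which carries bromo, inhibiting growth more strongly than compound 3, which carries hydrogen. Nothing available explains this difference, so the reason for it remains unknown.

The compounds shown leave open whether this step is particular to bromo or would also appear with another group on the same aromatic carbon, such as chloro, fluoro, methoxy or an amine. They also leave open whether hydrogen in place of bromo would give a similar step when piperidin-1-yl, as in compound 2, stands in place of dimethylamino on the chain carbon.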